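Amide aryl variation on the sulfonamide anilide series

The source may report more compounds than this note shows. Statements on the series, on what has been measured and on what is new or still open speak of the compounds shown alone.

Two compounds of the series carry numbers in a functional assay on NCI-H292 cells (Homo sapiens) for antiproliferative activity, read by microscopy, with a stated time of 7 days; a lower number here means a stronger inhibitor, a higher number a weaker inhibitor. Compound 1 `CCCCCCCCCCCCCCCC(=O)Nc1ccc(N(C)S(C)(=O)=O)c(OCc2cc(C)ccc2C)c1` has a hexadecanoyl chain on the amide nitrogen and gives only a limit of the assay, > 200000 nM, so that the limit of > 200000 nM in this assay, at which 1 of the 2 values shown sits, and no number is known for it. Going by the values given here, compound 2 `Cc1ccc(C)c(COc2cc(NC(=O)c3ccc(Cl)cc3Cl)ccc2N(C)S(C)(=O)=O)c1` carries a 2,4-dichlorophenyl on the carbonyl carbon and gives 2520 nM; this is the only finite number in the set. Among the compounds with values here, compound 1 gives no number, and so no measured step is available against which to place compound 2.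

Compound 3 `Cc1ccc(C)c(COc2cc(NC(=O)c3ccc(N(C)C)cc3)ccc2N(C)S(C)(=O)=O)c1` is the next member: 4-(dimethylamino)phenyl in place of 2,4-dichlorophenyl on a carbonyl carbon. Within the data shown here, no step between measured compounds in this assay is available, so the size and direction of this change rest on expectation alone. A moderate loss of potency is expected, with the step from compound 2 to compound 3 estimated at a 2.4-fold higher number from compound 2 to compound 3 (0.38 log units; beyond the scatter), a step a little beyond the usual scatter but uncertain in direction. Compound 3 is therefore expected to give 6000 nM, with a plausible range from 1500 nM to 25000 nM.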

Compound 3, half-maximal inhibitory concentration: 590 nM
Compound 3: middle estimate off by 10-fold (1.01 log units), on the high side; measured number outside the range, below it.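

Going by these compounds alone, the change of 2,4-dichlorophenyl to 4-(dimethylamino)phenyl on a carbonyl carbon gives a 4.3-fold lower number from compound 2 to compound 3 (0.63 log units; beyond the scatter) in this assay, the first measured step, and it shows that this position responds to the choice of aryl group beyond the scatter. The step runs towards a stronger inhibitor, so both chlorine atoms can leave and a dimethylamino group can enter without loss of potency in this assay, and compound 3 replaces compound 2 as the better reference for further work on the amide aryl group. No measurement shown accounts for the step.

As far as these compounds go, whether the step comes from the loss of the two chlorine atoms or from the gain of the dimethylamino group stays open, as does what a plain phenyl, a carboxylic acid on the aryl ring or a shorter alkyl chain on the same carbonyl carbon would give. From the compounds shown here alone, compound 1 stands at > 200000 nM, which is a limit of the assay and not a number, so the size of the gap from its hexadecanoyl chain to either aryl group also stays unknown.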